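Diethylamino in Place of Methyl on the Shared Core

This account rests on a few compounds, and the source may have more. Where it says the series, first, only, none or still open, it means among the compounds named here.

Compound 1 `Cc1ccc2nc(-c3ccccc3C(F)(F)F)[nH]c(=O)c2c1` gives only a limit, > 50000 nM.
Compound 2 `Cc1ccc2nc(-c3ccccc3OC(F)(F)F)[nH]c(=O)c2c1` gives only a limit, > 50000 nM.
Compound 3 `Cc1ccc2nc(-c3ccccc3C)[nH]c(=O)c2c1` gives only a limit, > 50000 nM.

In a functional assay on T47D cells (Homo sapiens) for cytotoxicity, read by MTT assay, with a stated time of 2 days (on this read-out lower numbers stand for stronger inhibition and higher numbers for weaker inhibition), compound 1 stands at the limit of the assay, not at a number. Because of the limit of > 50000 nM in this assay, at which 3 of the 3 values shown sit, the steps a step that the two limits leave unreadable from compound 1 to compound 2, a step that the two limits leave unreadable from compound 1 to compound 3 and a step that the two limits leave unreadable from compound 2 to compound 3 cannot be sized. Compound 4 `CCN(CC)c1ccc2nc(-c3ccccc3C(F)(F)F)[nH]c(=O)c2c1` arises from compound 1 by diethylamino in place of methyl on an aromatic carbon. Going by the values given here, no measured step touches this part of the core, so the measured steps give no direction for it. With three limits and no number, compound 4 is expected to stay at or near the limit, a step of a number no higher from compound 1 to compound 4 (the limit leaves the size open). The estimate for compound 4 is 50000 nM, with a range from 10000 nM to 100000 nM.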

Compound 4, half-maximal inhibitory concentration: 2550 nM
The estimate for compound 4 lay 20-fold (1.29 log units) above the measured number; measured number outside the range, below it.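

In this assay, diethylamino in place of methyl on this aromatic carbon gives an at least 19-fold lower number from compound 1 to compound 4 (1.29 log units; beyond the scatter). A change at this position of the shared core can therefore bring a compound down from the limit to a real number, which the earlier changes elsewhere on the molecule did not show. Compound 4 alone gives a number, and the steps among the other compounds still cannot be read: the limit of > 50000 nM in this assay, at which 3 of the 4 values shown sit.

Only one replacement at this position is shown, so it remains open whether the nitrogen or the ethyl chains matter. Dimethylamino, morpholine or a plain butyl chain at the same carbon could help separate the two.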